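Methoxy in place of trifluoromethyl on a shared phenol core

The compounds below may be only part of what the source reports. "The series", "measured", "known", "first", "only" and "open" are said of these compounds alone.

The numbers here come from a functional assay on HepG2 cells (Homo sapiens) for antiproliferative activity, read by MTT assay, with a stated time of 24 h; on this read-out higher numbers stand for weaker inhibition and lower numbers for stronger inhibition. Compound 1, `C=CCc1cc(-c2ccccc2C(F)(F)F)ccc1O`, gives 52400 nM in this assay. Compound 2, `C=CCc1cc(-c2cccc(C(F)(F)F)c2)ccc1O`, gives 58300 nM in this assay. These two figures sit within the scatter of each other, so compound 2 cannot be set apart from compound 1; it simply stands beside it among the two numbers recorded. Compound 3, `C=CCc1ccc(OCC)c(-c2ccc(OCC)c(CC=C)c2)c1`, reaches only a limit of this assay, > 124000 nM, and no number is recorded for it (the limit of > 124000 nM in this assay, at which 1 of the 3 values shown sits).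

Compound 4, `C=CCc1cc(-c2cccc(OC)c2)ccc1O`, has not yet been measured in this assay. It differs from compound 2 in one place: methoxy in place of trifluoromethyl on an aromatic carbon. Going by the values given here, no pair of measured compounds in this set differs by this same change, so there is no measured step to lean on, and the expectation rests on the two numbers of compound 1 and compound 2 alone, which lie close together. The expected step from compound 2 to compound 4 is therefore small, a 1.2-fold lower number from compound 2 to compound 4 (0.07 log units; within the scatter), with no direction beyond the scatter claimed. Compound 4 is expected to give about 50000 nM in this assay, with a range from 20000 nM to 120000 nM.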

Compound 4, half-maximal inhibitory concentration: > 100000 nM
Compound 4 was reported as a limit; the forecaster's own chance of this, stated with the estimate: 20%; middle value at least 2.0-fold (0.30 log units) away from the limit.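

In this assay compound 4 is recorded as a limit and not as a number: the limit of > 100000 nM in this assay, at which 1 of the 4 values shown sits.

Methoxy in place of trifluoromethyl on this aromatic carbon, meta to a large group, gives an at least 1.7-fold higher number from compound 2 to compound 4 (0.23 log units; that floor lies within the scatter). Going by these compounds alone, this is the first measured step at this position, and it shows that the change brings no stronger inhibition, although the floor of the step is too small to prove that inhibition became weaker.

The compounds shown leave open how far the true number of compound 4 lies past its limit, and so whether the loss is real and how large it might be. They also leave open whether the same change would act the same way in compound 1, and what an amine or a carboxylic acid on this aromatic carbon would give in this assay, where a group that differs more from both trifluoromethyl and methoxy could show whether this position responds to any change at all.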